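The source may report more compounds than this note shows. Statements on the series, on what has been measured and on what is new or still open speak of the compounds shown alone.

In a physicochemical assay for lipophilicity, read by HPLC, at pH 7.4 (on this read-out lower numbers stand for lower lipophilicity and higher numbers for higher lipophilicity), compound 1 (`C[C@@H](Oc1cc2oc(=O)n(CCC(=O)O)c2cc1Cl)c1cccnn1`) reads 0.83 and compound 2 (`C[C@@H](Oc1cc2oc(=O)n(CCC(=O)O)c2cc1Cl)c1ncccn1`) reads 0.83, so compound 2 stands level with compound 1. Compound 3 (`Cc1cccc([C@@H](C)Oc2cc3oc(=O)n(CCC(=O)O)c3cc2Cl)n1`) carries 6-methylpyridin-2-yl in place of pyrimidin-2-yl on a saturated chain carbon bound to an oxygen on an aromatic ring and a saturated chain carbon. Within the data shown here, the only measured step, no change at the digits printed from compound 1 to compound 2 (within the scatter), exchanged one ring with 2 hetero atoms for another with 2 hetero atoms. Among the measured compounds shown here, no measured step covers a ring with 1 hetero atom or an added carbon. Resting on the structural change alone, an upward step beyond the scatter is expected in this assay: a number 0.87 log units higher from compound 2 to compound 3 (beyond the scatter). For compound 3 the estimate is 1.7, with an expected range of 1.2 to 2.2.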

Compound 3, distribution coefficient: 2.12
Estimate against measurement, compound 3: 0.42 log units below; the measured number falls inside the stated range.
By their numbers in this assay, from the lowest: compounds 1 and 2 (each within the scatter of the next); then compound 3.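

At this position, on a saturated chain carbon bound to an oxygen on an aromatic ring and a saturated chain carbon, the group can shift the read-out in this assay: a number 1.29 log units higher from compound 2 to compound 3 (beyond the scatter), and a number 1.29 log units higher from compound 1 to compound 3 (beyond the scatter). Both steps are large, whereas the exchange between the two rings with 2 hetero atoms left the printed digits unchanged. Nothing measured here bears on the origin of these steps.

The change joins a ring with 1 hetero atom to an added methyl, so their shares stay undivided. Pyridin-2-yl and 6-methylpyrimidin-2-yl at this place would separate them.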